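The compounds below may be only part of what the source reports. "The series", "measured", "known", "first", "only" and "open" are said of these compounds alone.

In a functional assay on MDA-MB-231 cells (Homo sapiens) for cytotoxicity, read by MTT assay, with a stated time of 72 h (on this read-out lower numbers stand for stronger inhibition and higher numbers for weaker inhibition), compound 1 `O=C(Nc1ccc(-n2ncc3c(Cl)cccc32)cc1)Nc1ccc(Cl)c(C(F)(F)F)c1` gives 1600 nM, compound 2 `O=C(Nc1ccc(-n2ncc3ccccc32)cc1)Nc1ccc(Cl)c(C(F)(F)F)c1` gives 5000 nM, and compound 3 `O=C(Nc1ccc(-n2ncc3cnccc32)cc1)Nc1ccc(Cl)c(C(F)(F)F)c1` gives 16000 nM, so compound 3 stands highest of the three numbers, with compound 2 nearest and compound 1 furthest. Compound 4 `O=C(Nc1ccc(-n2ncc3ccncc32)cc1)Nc1ccc(Cl)c(C(F)(F)F)c1` has the same atoms as compound 3, joined differently: a group of 9 heavy atoms (6 carbon, 3 nitrogen; one five-membered aromatic ring with 2 hetero atoms, one six-membered aromatic ring with 1 hetero atom) in place of a group of 9 heavy atoms (6 carbon, 3 nitrogen; one five-membered aromatic ring with 2 hetero atoms, one six-membered aromatic ring with 1 hetero atom), on an aromatic carbon. Among the measured compounds shown here, none of the measured steps rearranges a group within itself; each swaps or strips part of the group. From compound 1 to compound 2 the step is a 3.1-fold higher number from compound 1 to compound 2 (0.49 log units; beyond the scatter), from compound 2 to compound 3 it is a 3.2-fold higher number from compound 2 to compound 3 (0.51 log units; beyond the scatter), and from compound 1 to compound 3 it is a 10-fold higher number from compound 1 to compound 3 (1.00 log units; beyond the scatter). These show that this assay answers to changes in this group, but nothing among the three tests a relocation of the hetero atom within the six-membered aromatic ring with 1 hetero atom. The expected step is therefore no change at the digits printed from compound 3 to compound 4 (within the scatter), none beyond the scatter, held with wide uncertainty. Compound 4 is estimated at 16000 nM, between 5000 nM and 50000 nM.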

Compound 4, half-maximal inhibitory concentration: > 32000 nM
Compound 4 ended at the assay's limit; the forecaster's own chance of this, stated with the estimate: 10%; middle value at least 2.0-fold (0.30 log units) from the limit.
By their numbers in this assay, from the lowest: compound 1; then compound 2; then compound 3. At a limit, above all of these: compound 4.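

In this assay compound 4 gives a limit, not a number: the limit of > 32000 nM in this assay, at which 1 of the 4 values shown sits.

Moving the nitrogen within the six-membered aromatic ring with 1 hetero atom gives an at least 2.0-fold higher number from compound 3 to compound 4 (0.30 log units; that floor lies within the scatter), so this first test of a relocation yields only a floor and does not establish that the nitrogen's placement matters. Among the compounds shown here, measured from the carbon-only compounds, the gap is clearer, with an at least 6.4-fold higher number from compound 2 to compound 4 (0.80 log units; beyond the scatter) and an at least 20-fold higher number from compound 1 to compound 4 (1.30 log units; beyond the scatter), the latter being the first step printed as large.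

As far as these compounds go, it remains open how far compound 4 lies past its limit, and therefore whether compound 3 and compound 4 truly differ. Also open, from the compounds shown here alone, is whether the lower number seen with chloro in compound 1 carries over to fluoro, methyl or an amine at that carbon, or to chloro on a ring that holds the extra nitrogen.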